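Half-life across the arylmethyl variants of the series

A few compounds are considered here, and "the series" means these few. Any claim that something is new, unique, unknown or untested is made for them only; others in the source may bear on it.

Compound 1 `Nc1ccc(CN2CCN(c3ccc(N4C[C@H](Cn5ccnn5)OC4=O)cc3F)CC2)cc1` is the reference of this set; in an in vivo ADME assay on the whole organism (strain Sprague-Dawley) for metabolic stability, with Rattus norvegicus as the target, at a dose of 10 mg/kg by the intravenous route (a higher number here means that the compound lasts longer, a lower number that the compound disappears faster), compound 1 gives 3.52 h. Compound 2 `O=C1O[C@@H](Cn2ccnn2)CN1c1ccc(N2CCN(Cc3ccc([N+](=O)[O-])o3)CC2)c(F)c1` gives 1.18 h in this assay, and compound 3 `O=C1O[C@@H](Cn2ccnn2)CN1c1ccc(N2CCN(Cc3cccc([N+](=O)[O-])c3)CC2)c(F)c1` gives 2.95 h. Among the three numbers compound 3 stands second highest: its gap to compound 1 lies within the scatter a 1.2-fold lower number from compound 1 to compound 3 (0.08 log units; within the scatter), while its gap to compound 2 is the one clear difference in the set a 2.5-fold higher number from compound 2 to compound 3 (0.40 log units; beyond the scatter).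

Compound 4 `O=C1O[C@@H](Cn2ccnn2)CN1c1ccc(N2CCN(Cc3ccoc3)CC2)c(F)c1` carries the change (furan-3-yl in place of 3-nitrophenyl on a saturated chain carbon bound to an amine nitrogen in a ring). The precedents are all swaps at the same place. a 1.2-fold lower number from compound 1 to compound 3 (0.08 log units; within the scatter) shows that 4-aminophenyl and 3-nitrophenyl give numbers within the scatter of each other, whereas a 3.0-fold lower number from compound 1 to compound 2 (0.47 log units; beyond the scatter) and a 2.5-fold higher number from compound 2 to compound 3 (0.40 log units; beyond the scatter) show that the 5-nitrofuran-2-yl compound sits clearly lower than either. Furan-3-yl carries no nitro group, so the two measured steps involving compound 2 do not transfer directly; the step to compound 4 is expected to be smaller than those, and on balance the half-life in this assay is more likely to fall than to rise. The expected step is a 1.5-fold lower number from compound 3 to compound 4 (0.17 log units; within the scatter), which stays within the scatter. For compound 4 the estimate in this assay is 2 h, with a range from 1 h to 3.8 h.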

Compound 4, half-life: 2.95 h
Estimate against measurement, compound 4: 1.5-fold (0.17 log units) below, within the range that was stated.
By their numbers in this assay, from the lowest: compound 2; then compounds 3, 4 and 1 (each within the scatter of the next).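

Notes on the arylmethyl position: on a saturated chain carbon bound to an amine nitrogen in a ring, furan-3-yl in place of 3-nitrophenyl gives no change at the digits printed from compound 3 to compound 4 (within the scatter) in this assay, so a group of 5 heavy atoms without a nitro group reads the same here as one of 9 heavy atoms with it. For the compounds shown here, the comparison with the aniline-bearing reference gives the same reading (a 1.2-fold lower number from compound 1 to compound 4 (0.08 log units; within the scatter)), while the step from the nitrofuran (a 2.5-fold higher number from compound 2 to compound 4 (0.40 log units; beyond the scatter)) shows that a furan ring alone does not go with the low number, and compound 2 remains the only compound of the four that stands apart. Nothing on hand bears on why the numbers at this position fall as they do.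

Still open, from the compounds shown here alone, is whether the low number of compound 2 goes with the nitro group on the furan or with attachment through furan-2-yl rather than furan-3-yl. Unsubstituted furan-2-yl and 5-nitrofuran-3-yl at this place would separate those two readings, and a saturated ring such as tetrahydrofuran-3-yl or a plain alkyl chain would show whether an aromatic ring is needed here at all.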